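The source may report more compounds than this note shows. Statements on the series, on what has been measured and on what is new or still open speak of the compounds shown alone.

In a functional assay on K562 cells (Homo sapiens) (a lower number here means a stronger inhibitor, a higher number a weaker inhibitor), compound 1 `CCCNC(=O)Nc1ccc(C(C)C)cc1` gives 54000 nM, compound 2 `CNC(=O)Nc1ccc(C(C)C)cc1` gives 198000 nM, and compound 3 `CCNC(=O)Nc1ccc(C(C)C)cc1` gives 142000 nM. Compound 2 therefore sits at the weak end of this small set, level with compound 3 within the scatter. Compound 4 `CCC(C)c1ccc(NC(=O)NC)cc1` differs from compound 2 as follows: methyl in place of hydrogen on a saturated chain carbon, two bonds along the chain from an aromatic carbon. This is methyl in place of hydrogen on a saturated chain carbon, two bonds along the chain from an aromatic carbon. Within the data shown here, no measured step touches this group, so the only guides come from the other chain. Adding methyl there gave a 1.4-fold lower number from compound 2 to compound 3 (0.14 log units; within the scatter), while removing ethyl gave a 3.7-fold higher number from compound 1 to compound 2 (0.56 log units; beyond the scatter). A small shift toward a lower number is therefore expected, a 1.7-fold lower number from compound 2 to compound 4 (0.22 log units; within the scatter). Compound 4 is estimated at 120000 nM, with an expected range of 60000 nM to 210000 nM.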

Compound 4, half-maximal inhibitory concentration: 142000 nM
The estimate for compound 4 lay 1.2-fold (0.07 log units) below the measured number; low and high end bracket the measured number.
By their numbers in this assay, from the lowest: compound 1; then compounds 3, 4 and 2 (each within the scatter of the next).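

In this assay, the change from isopropyl to sec-butyl gives a 1.4-fold lower number from compound 2 to compound 4 (0.14 log units; within the scatter), so one added methyl at this position, two bonds along the chain from an aromatic carbon, causes no shift that can be told from scatter. The same change can now also be compared across two cores, and the two steps agree within the scatter: the same change on two cores in this assay, a 2.6-fold higher number (0.42 log units; beyond the scatter) from compound 1 to compound 3 and a 1.4-fold higher number (0.14 log units; within the scatter) from compound 4 to compound 2, 1.9-fold (0.28 log units) apart, within the scatter of two such steps

A single methyl is the only change shown here, so it remains open how a longer chain such as n-hexyl would behave. From the compounds shown here alone, the effect of a carboxylic acid or an amine at this position also remains open.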